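Hydroxymethyl Added to the Methylamino Chain of Compound 3

The source may hold more compounds than are shown below. What is called first, only, known or untested is meant among the compounds shown, and "the series" means these compounds.

Compound 3 `CCCS(=O)(=O)Nc1ccc(F)c(NC(=O)Nc2cc(NC)ncn2)c1F` gives 900 ug/mL in a physicochemical assay for solubility, using the shake flask method, measured as thermodynamic solubility, with a stated time of 24 h, at pH 1.2, tested at 0.5 mg/mL (a higher number here means a more soluble compound, a lower number a less soluble compound), the highest of the three numbers at hand. Compound 2 `Nc1ncnc2c(C(=O)Nc3c(Cl)ccc(NS(=O)(=O)CCCF)c3F)csc12` gives 700 ug/mL in this assay, which lies within the scatter of the number for compound 3, so no order between the two can be read. Among the measured compounds shown here, compound 1 `CCCS(=O)(=O)Nc1ccc(F)c(NC(=O)Nc2ncnc3[nH]ncc23)c1F` gives 7 ug/mL in this assay, and the step of a 130-fold higher number from compound 1 to compound 3 (2.11 log units; beyond the scatter) is the one large change among the measured compounds; it exchanges one ring system for another on an amide-type nitrogen. Compound 4 `CCCS(=O)(=O)Nc1ccc(F)c(NC(=O)Nc2cc(NCCO)ncn2)c1F` differs from compound 3 by hydroxymethyl in place of hydrogen on a saturated chain carbon bound to a nitrogen on an aromatic ring. For the measured compounds named here, no measured step touches this chain: the only step available concerns a ring system and not the methylamino group, so it offers no direct guide to the size of the change from compound 3 to compound 4. Compound 4 is therefore expected to sit close to compound 3, with the step of no change at the digits printed from compound 3 to compound 4 (within the scatter) estimated to remain within the scatter. The estimate for compound 4 in this assay is 900 ug/mL, with a range from 400 ug/mL to 1800 ug/mL.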

Compound 4, solubility: 900 ug/mL
The estimate for compound 4 equals the measured number at the digits printed; measured number inside the range.
By their numbers in this assay, from the lowest: compound 1; then compounds 2, 3 and 4 (each within the scatter of the next).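

In this assay, among the compounds shown here, the new step reads no change at the digits printed from compound 3 to compound 4 (within the scatter), and it is the first measured step that touches the methylamino chain, with hydroxymethyl in place of hydrogen on a saturated chain carbon bound to a nitrogen on an aromatic ring. For the compounds shown here, the only earlier step, a 130-fold higher number from compound 1 to compound 3 (2.11 log units; beyond the scatter), exchanged one ring system for another on an amide-type nitrogen and said nothing about this chain, whereas the exchange of methylamino for (2-hydroxyethyl)amino now shows that this one change leaves the number as it stood. Nothing at hand gives a reason for this outcome.

The compounds shown leave open whether a different group on this chain would also leave the number as it stands, such as a longer chain ending in hydroxyl, a primary amine or a carboxylic acid. They also leave open whether the same exchange would give the same result on the core of compound 1 or of compound 2, neither of which carries the methylamino chain.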